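Second chloro on the purine-type core of compound 1

The source may report more compounds than this note shows. Statements on the series, on what has been measured and on what is new or still open speak of the compounds shown alone.

Measured compounds:
compound 1 `ClCc1ccc(Cn2cnc3c(Cl)ncnc32)cc1` 4360 nM
compound 2 `ClCc1cccc(Cn2cnc3c(Cl)ncnc32)c1` 21900 nM
compound 3 `ClCc1ccc(Cn2cnc3nc(Cl)nc(Cl)c32)cc1` 1120 nM

In a functional assay on SK-MEL-2 cells (Homo sapiens) for cytotoxicity, read by sulforhodamine B assay, with a stated time of 48 h (on this read-out higher numbers stand for weaker inhibition of growth and lower numbers for stronger inhibition of growth), compound 1 gives 4360 nM, the second highest of the three numbers. Compound 2, which carries its chloromethyl group elsewhere on the benzyl ring, gives 21900 nM, a higher number that lies beyond the scatter. Compound 3, which bears two chloro groups on its fused core in a different arrangement, gives 1120 nM, a lower number, again beyond the scatter.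

Compound 4 `ClCc1ccc(Cn2cnc3c(Cl)nc(Cl)nc32)cc1` is not yet measured. It differs from compound 1 by chloro in place of hydrogen on an aromatic carbon. Among the compounds with values here, no step between two measured compounds shows exactly this change. Within the data shown here, because compound 3, the only other compound with two chloro groups on the core, gives 1120 nM, a move to a lower number, meaning stronger growth inhibition, is expected, of modest size. The estimate for compound 4 in this assay is 1800 nM, with a range from 600 nM to 5000 nM, an expected step of a 2.4-fold lower number from compound 1 to compound 4 (0.38 log units; beyond the scatter).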

Compound 4, concentration for 50% growth inhibition: 20000 nM
Compound 4: the middle estimate sits 11-fold (1.05 log units) below what was measured, outside the stated range (above it).
By their numbers in this assay, from the lowest: compound 3; then compound 1; then compounds 4 and 2 (each within the scatter of the next).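

In this assay, chloro in place of hydrogen on this aromatic carbon, between two ring nitrogen atoms, gives a 4.6-fold higher number from compound 1 to compound 4 (0.66 log units; beyond the scatter), which means weaker inhibition of growth. Within the data shown here, this is the first measured step at this position, and it shows that this single added chlorine atom is enough to move the read-out beyond the scatter, here toward weaker inhibition. No measurement shown here explains why this change has that effect.

On these data alone, it remains open how the number would move with another group on this same carbon, such as an amine or a methoxy group. Also open, as far as these compounds go, is whether chloro here would give a step of similar direction and size with the chloromethyl group placed as in compound 2.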